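Amide group changes on the shared core: cyclopropylamino step

The source may hold more compounds than are shown below. What is called first, only, known or untested is meant among the compounds shown, and "the series" means these compounds.

- compound 1 `NNC(=O)COc1ccncc1-c1ccc2ccccc2c1` has the entry "not determined" (no result reported) on record
- compound 2 `COC1CN(C(=O)/C=C/c2ccncc2-c2ccc3ccccc3c2)C1` gives > 30000 nM as a limit
- compound 3 `CN(C)C(=O)/C=C/c1ccncc1-c1ccc2ccccc2c1` gives 4540 nM as a number

Among the measured compounds shown here, in a functional assay on HCT-116 cells (Homo sapiens) for inhibition, read by MTT assay, with a stated time of 72 h (on this read-out higher numbers stand for weaker inhibition of growth and lower numbers for stronger inhibition of growth), compound 3 at 4540 nM holds the only actual number of the set, and compound 1 has no result. Compound 2 shows > 30000 nM and this is a limit only.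

Compound 4 `O=C(/C=C/c1ccncc1-c1ccc2ccccc2c1)NC1CC1` carries the change cyclopropylamino in place of dimethylamino on a carbonyl carbon and so has cyclopropylamino in place of dimethylamino on a carbonyl carbon. For the measured compounds named here, one measured step bears on it at that same carbon, namely an at least 6.6-fold lower number from compound 2 to compound 3 (0.82 log units; beyond the scatter) for dimethylamino in place of 3-methoxyazetidin-1-yl, and it lies beyond the scatter. That single step shows that the group at this place can matter, but it does not fix a direction for cyclopropylamino. A modest move towards weaker inhibition of growth is expected, with the direction uncertain. The expected step is a 1.4-fold higher number from compound 3 to compound 4 (0.16 log units; within the scatter) as an estimate. The estimate for compound 4 is 6500 nM with an expected range of 2000 nM to 20000 nM in this assay for this series.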

Compound 4, concentration for 50% growth inhibition: 6180 nM
For compound 4 the middle estimate is 1.1-fold (0.02 log units) above the measured one; low and high end bracket the measured number.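

In this assay, cyclopropylamino on the carbonyl carbon brings a three-membered ring and a hydrogen-bond donor that dimethylamino lacks, yet the read-out does not separate the two groups: a 1.4-fold higher number from compound 3 to compound 4 (0.13 log units; within the scatter). The gap to the 3-methoxyazetidin-1-yl amide now holds for a second group at this place, with an at least 4.8-fold lower number from compound 2 to compound 4 (0.68 log units; beyond the scatter). Compound 2 is held only by a limit, so the true size of both gaps to it is unknown: the limit of > 30000 nM in this assay, at which 1 of the 4 values shown sits.

The compounds shown leave open whether an unsubstituted amide, a longer alkyl chain on the amide nitrogen or a chain ending in an amine would move the number beyond the scatter from compound 3 and compound 4. They also leave open whether any group at this place gives clearly stronger inhibition of growth than these two.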